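Series notes: aryl-thio dihydropyrimidine carboxanilides, single-dose inhibition

The source may report more compounds than this note shows. Statements on the series, on what has been measured and on what is new or still open speak of the compounds shown alone.

Measured so far:
compound 1 `COc1ccc(C2N=C(SCc3ccc(Cl)cc3)NC(C)=C2C(=O)Nc2ccc(F)cc2)cc1OC` gives 31.3% in a functional assay on the whole organism (artery, strain albino) with Rattus norvegicus as the target, with a stated time of 300 min, at a dose of 10 mg/kg by the oral route; a lower number here means less inhibition, a higher number more inhibition at the dose given (going by the name of the read-out)
compound 2 `CC1=C(C(=O)Nc2ccc(Br)cc2)C(c2ccc(Cl)cc2Cl)N=C(SCc2ccccc2Cl)N1` gives 36.4% in this assay

Where compound 2 stands: only two numbers exist in this assay, and compound 2 with 36.4% and compound 1 with 31.3% lie within the usual scatter of each other, so no order between them can be read from these data. Among the compounds with values here, no step between compounds differing in one place has been measured, so no single change has yet been tied to a change in the read-out.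

The next step goes from compound 2 to compound 3 `CC1=C(C(=O)Nc2ccc(Br)cc2)C(c2ccc(Cl)cc2Cl)N=C(SCc2ccc(Cl)cc2)N1`, which is still to be measured in this assay. The change is 4-chlorophenyl in place of 2-chlorophenyl on a saturated chain carbon bound to a sulfur. Within the data shown here, the 4-chlorobenzyl group is the one carried by compound 1, and the two values of compound 1 and compound 2 differ only within the scatter, so nothing in the data points to a step beyond the scatter in either direction.

For compound 3 the expected step of a number 2.4 percentage points lower from compound 2 to compound 3 (within the scatter) is small. Compound 3 is expected to give 34% in this assay, with a range of 22% to 46%.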

Compound 3, a percentage reported as inhibition, in the whole organism at one dose (the size of the read-out at that dose, not a potency): 38.5%
Beside the measured number, compound 3's estimate is 4.5 percentage points below it, within the range that was stated.
By their numbers in this assay, from the lowest: compounds 1, 2 and 3 (each within the scatter of the next).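

In this assay, within the data shown here, the exchange of 2-chlorophenyl for 4-chlorophenyl on a saturated chain carbon bound to a sulfur gives a number 2.1 percentage points higher from compound 2 to compound 3 (within the scatter) and is the first step that isolates a single place, with the rest of the compound unchanged. The two groups have the same atoms, joined differently, so at this position and at this single oral dose the read-out does not separate 2-chlorobenzyl from 4-chlorobenzyl. Nothing measured here offers an explanation for this result.

Compound 1 and compound 3 both carry the 4-chlorobenzyl group but differ elsewhere, so their printed values cannot be tied to any one place. Among these compounds, open at the sulfur is whether an unsubstituted benzyl group, a longer chain between the sulfur and the phenyl ring, or a carboxylic acid or an amine on that ring would give a step beyond the usual scatter, since the two chlorobenzyl groups show only that this one exchange leaves the read-out within it.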